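The source may hold more compounds than are shown below. What is called first, only, known or untested is meant among the compounds shown, and "the series" means these compounds.

Measured compounds in an assay on isolated protein for inhibition of coagulation factor X (Oryctolagus cuniculus), tested at 1 uM; a lower number here means less inhibition, a higher number more inhibition at the concentration tested (going by the name of the read-out):
Compound 1, `CC(C)(C)c1ccc(S(=O)(=O)N[C@H]2CCN(CCNc3ccncc3)C2=O)cc1`, gives 14%.
Compound 2, `O=C1[C@@H](NS(=O)(=O)c2cc3cccnc3s2)CCN1Cc1cc2[nH]cccc-2n1`, gives 44%.
Compound 3, `O=C1[C@@H](NS(=O)(=O)c2cc3cccnc3s2)CCN1Cc1cc2c[nH]ccc-2n1`, gives 18%.

Compound 3 holds the second highest of the three numbers in this assay; its gap to compound 1 lies within the scatter, while the step of a number 26 percentage points lower from compound 2 to compound 3 (beyond the scatter) is beyond it. Compound 4, `O=C1[C@@H](NS(=O)(=O)c2cc3nc(Cl)ccc3s2)CCN1Cc1cc2c[nH]ccc-2n1`, differs from compound 3 at the sulfonyl sulfur: a group of 10 heavy atoms (7 carbon, 1 nitrogen, 1 sulfur, 1 chlorine; one five-membered aromatic ring with 1 hetero atom, one six-membered aromatic ring with 1 hetero atom) in place of a group of 9 heavy atoms (7 carbon, 1 nitrogen, 1 sulfur; one five-membered aromatic ring with 1 hetero atom, one six-membered aromatic ring with 1 hetero atom), on a sulfonyl sulfur. Going by the values given here, no measured step touches this part of the molecule; the only step on record, from compound 2 to compound 3, alters the group on the saturated chain carbon instead. With nothing to anchor the change, the estimate for compound 4 assumes a step of a number 6 percentage points higher from compound 3 to compound 4 (within the scatter), not beyond the scatter, and compound 4 is therefore expected to give about 24%, between 6% and 52%.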

Compound 4, a percentage reported as inhibition, at one concentration (the size of the read-out at that concentration, not a potency): 58%
Compound 4: the middle estimate sits 34 percentage points below what was measured; measured number above the stated range.
By their numbers in this assay, from the lowest: compounds 1 and 3 (each within the scatter of the next); then compound 2; then compound 4.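

The group on a sulfonyl sulfur turns out to be a place where this assay responds strongly: exchanging it for the chlorine-bearing group gives a number 40 percentage points higher from compound 3 to compound 4 (beyond the scatter). Previously, only the group on the saturated chain carbon had been seen to shift this number. Nothing available here explains the rise.

On these data alone, the entering group carries a chlorine but also differs in the arrangement of its ring atoms, so the part played by the chlorine alone remains open. As far as these compounds go, whether a methyl group or a bromine atom in its place would give a similar number also remains open.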